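The source may report more compounds than this note shows. Statements on the series, on what has been measured and on what is new or still open speak of the compounds shown alone.

Compound 1 `O=C(CN1CCN(S(=O)(=O)c2ccccc2F)CC1)Nc1ccccc1F`: 8000 nM
Compound 2 `O=C(CN1CCN(S(=O)(=O)c2ccccc2)CC1)Nc1ccccc1F`: 4100 nM
Compound 3 `COc1ccc(S(=O)(=O)N2CCN(CC(=O)Nc3ccccc3F)CC2)cc1`: 13400 nM

In an in vitro assay on HEK ts201 cells for negative allosteric modulation of Neuronal acetylcholine receptor; alpha4/beta2 (Homo sapiens), read by fluorescence and calcium flux, with a stated time of 1.5 s (on this read-out higher numbers stand for weaker inhibition and lower numbers for stronger inhibition), compound 1 gives the second highest of the three numbers; compound 3 stands nearest to it, a 1.7-fold higher number from compound 1 to compound 3 (0.22 log units; within the scatter), and compound 2 furthest, a 2.0-fold lower number from compound 1 to compound 2 (0.29 log units; within the scatter). Compound 4 `COC(=O)c1ccc(NC(=O)CN2CCN(S(=O)(=O)c3ccccc3F)CC2)cc1` arises from compound 1 by 4-(methoxycarbonyl)phenyl in place of 2-fluorophenyl on an amide-type nitrogen. Within the data shown here, none of the measured steps touches this amide-type nitrogen: the steps from compound 1 to compound 2 and from compound 1 to compound 3 altered the group on the sulfonyl sulfur, as did the step of a 3.3-fold higher number from compound 2 to compound 3 (0.51 log units; beyond the scatter), and only that last one went beyond the scatter. Among the measured compounds shown here, with no step at the amide-type nitrogen to draw on, the expected change for compound 4 is none beyond the scatter, no change at the digits printed from compound 1 to compound 4 (within the scatter). Compound 4 is therefore estimated at 8000 nM, within 2500 nM to 25000 nM.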

Compound 4, half-maximal inhibitory concentration: 12400 nM
The estimate for compound 4 lay 1.6-fold (0.19 log units) below the measured number; measured number inside the range.
By their numbers in this assay, from the lowest: compounds 2, 1, 4 and 3 (each within the scatter of the next, the first and the last beyond it).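

In this assay, replacing 2-fluorophenyl with 4-(methoxycarbonyl)phenyl on the amide-type nitrogen gives a 1.6-fold higher number from compound 1 to compound 4 (0.19 log units; within the scatter). Among these compounds, this is the first view of that position, and it shows that this exchange of one aromatic group for another, with the added methoxycarbonyl, leaves the number within the scatter. No available evidence accounts for this result. The compounds shown leave open whether an amine or a carboxylic acid in place of the methoxycarbonyl would do the same. They also leave open what a longer chain on this nitrogen would do.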